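Exchanging the aryl on the triazole nitrogen of compound 3

The source may hold more compounds than are shown below. What is called first, only, known or untested is meant among the compounds shown, and "the series" means these compounds.

Compound 3 `CCc1ccccc1-n1nncc1CN1C(=O)C2(C(C#N)=C(N)Oc3c(N)cc4nc5ccccc5nc4c32)c2ccccc21` gives 10300 nM in a functional assay on HCT-116 cells (Homo sapiens) for antiproliferative activity, read by MTT assay, with a stated time of 48 h (on this read-out higher numbers stand for weaker inhibition and lower numbers for stronger inhibition), the lowest of the two numbers in hand. Compound 2 `N#CC1=C(N)Oc2c(c3nc4ccccc4nc3c3ccccc23)C12C(=O)N(Cc1cnnn1-c1cccc(S(N)(=O)=O)c1)c1ccccc12` stands nearest to it in this assay with 11300 nM, a gap within the scatter, so the two cannot be ranked. Compound 1 `N#CC1=C(N)Oc2c(c3nc4ccccc4nc3c3ccccc23)C12C(=O)N(Cc1cnnn1-c1ccc([N+](=O)[O-])cc1)c1ccccc12` gives only a limit in this assay, > 50000 nM; this is the limit of > 50000 nM in this assay, at which 1 of the 3 values shown sits.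

Compound 4 `N#CC1=C(N)Oc2c(N)cc3nc4ccccc4nc3c2C12C(=O)N(Cc1cnnn1-c1c(F)cccc1F)c1ccccc12` differs from compound 3 in one place: 2,6-difluorophenyl in place of 2-ethylphenyl on an aromatic nitrogen. A single measured step touches the same position, an at least 4.4-fold lower number from compound 1 to compound 2 (0.64 log units; beyond the scatter), but it only sets a floor on the change and involved different groups, one of them carrying a sulfamoyl. Within the data shown here, it therefore offers little guidance for an exchange of 2-ethylphenyl for 2,6-difluorophenyl, and no other step in this assay speaks to it.

On that basis compound 4 is expected to sit close to compound 3 in this assay, at an estimated 10000 nM with a range of 4000 nM to 30000 nM, which would mean a 1.0-fold lower number from compound 3 to compound 4 (0.01 log units; within the scatter), a step not expected to go beyond the scatter.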

Compound 4, half-maximal inhibitory concentration: > 50000 nM
Compound 4: no number, only a limit (the forecaster's own chance of this, stated with the estimate: 15%); middle value at least 5.0-fold (0.69 log units) away from the limit.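

In this assay, the step from 2-ethylphenyl to 2,6-difluorophenyl is an at least 4.8-fold higher number from compound 3 to compound 4 (0.68 log units; beyond the scatter), so the aryl on this aromatic nitrogen also matters on the core of compound 3, whereas the earlier step at this position was on the core of compound 1. The two groups match in their counts of heavy atoms, hydrogen-bond donors and acceptors and in having no net charge, so those counts alone do not separate them. Compound 4 gives only a limit, so the step marks a floor and not a size: the limit of > 50000 nM in this assay, at which 2 of the 4 values shown sit.

From the compounds shown here alone, it remains open what plain phenyl or 2-fluorophenyl would give on the core of compound 3, so the step cannot yet be divided between losing the ethyl and gaining the two fluorines. Also open, going by these compounds, is whether 3-sulfamoylphenyl would give a similar number on that core as it does in compound 2.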